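Amino-azole replacements on the diaryl ether aniline core

The source may hold more compounds than are shown below. What is called first, only, known or untested is meant among the compounds shown, and "the series" means these compounds.

Measured compounds:
- compound 1, `Nc1cc(Nc2ccc(Oc3ccc(Cl)cc3)cc2)ncn1` — in an in vitro ADME assay on microsomes from liver (Rattus norvegicus) for metabolic stability (on this read-out higher numbers stand for fast clearance and lower numbers for slow clearance), compound 1 gives 32 mL.min-1.g-1
- compound 2, `Nc1nsc(Nc2ccc(Oc3ccc(Cl)cc3)cc2)n1` — compound 2 gives < 14 mL.min-1.g-1, which is a limit of the assay and not a number

Compound 1 carries the only actual number shown in this assay; the other value shown is a limit. Compound 3, `Nc1nnc(Nc2ccc(Oc3ccc(Cl)cc3)cc2)s1`, is not yet measured. It differs from compound 1 in one place: 5-amino-1,3,4-thiadiazol-2-yl in place of 6-aminopyrimidin-4-yl on a nitrogen on an aromatic ring.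

Among the compounds with values here, the one measured step that bears on this change is an at least 2.2-fold lower number from compound 1 to compound 2 (0.35 log units; beyond the scatter), with compound 2 sitting at the limit (the limit of < 14 mL.min-1.g-1 in this assay, at which 1 of the 2 values shown sits). The change to compound 3 is of the same kind, a small amino-bearing five-membered ring in place of the six-membered one, so a step in the same direction and of comparable size is expected, a 2.3-fold lower number from compound 1 to compound 3 (0.36 log units; beyond the scatter). Compound 3 is therefore expected to give about 14 mL.min-1.g-1 in this assay, estimated within 7 mL.min-1.g-1 to 28 mL.min-1.g-1, with a fair chance that only a limit is reported.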

Compound 3, intrinsic clearance in microsomes: < 14 mL.min-1.g-1
Compound 3 ended at the assay's limit; the forecaster's own chance of this, stated with the estimate: 50%; the middle value lies on the limit itself.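

In this assay, the 5-amino-1,3,4-thiadiazol-2-yl group on the nitrogen gives an at least 2.2-fold lower number from compound 1 to compound 3 (0.35 log units; beyond the scatter), so a second arrangement of the five-membered aromatic ring moves the read-out the same way as the first, which gave an at least 2.2-fold lower number from compound 1 to compound 2 (0.35 log units; beyond the scatter). The value of compound 3 is a limit of the assay and not a number, and such limits now make up most of the set: the limit of < 14 mL.min-1.g-1 in this assay, at which 2 of the 3 values shown sit. The step between compound 2 and compound 3 cannot be read, so the two thiadiazolyl groups cannot be ranked against each other.

On these data alone, how far the true clearance of compound 2 and compound 3 lies under the limit stays open. Also open, as far as these compounds go, is whether a sulfur-free five-membered ring such as 5-amino-1,3,4-oxadiazol-2-yl would give a step in the same direction.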